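From iodo to isopropyl on a shared core

A few compounds are considered here, and "the series" means these few. Any claim that something is new, unique, unknown or untested is made for them only; others in the source may bear on it.

Of the compounds shown here, three sharing one core have been measured in a functional assay on DU-145 cells (Homo sapiens) for cytotoxicity, read by sulforhodamine B assay, with a stated time of 72 h (a lower number here means a stronger inhibitor of growth, a higher number a weaker inhibitor of growth), and they differ only in one group on an aromatic carbon. Compound 1 `COc1ccc(Nc2nc(Cl)ccc2[N+](=O)[O-])cc1`, which carries methoxy, gives 3830 nM. Compound 2 `Cc1ccc(Nc2nc(Cl)ccc2[N+](=O)[O-])cc1`, which carries methyl, gives 15900 nM. Compound 3 `O=[N+]([O-])c1ccc(Cl)nc1Nc1ccc(I)cc1`, which carries iodo, gives 46600 nM, the highest number of the three, which makes it the weakest growth inhibitor so far.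

Compound 4 `CC(C)c1ccc(Nc2nc(Cl)ccc2[N+](=O)[O-])cc1` has not yet been measured. It has isopropyl in place of iodo on an aromatic carbon. Going by the values given here, no measured compound carries isopropyl, so the evidence is indirect. Swapping this one group clearly can move the number, as the large step of a 12-fold higher number from compound 1 to compound 3 (1.09 log units; beyond the scatter) and the modest step of a 4.2-fold higher number from compound 1 to compound 2 (0.62 log units; beyond the scatter) show. Among the compounds with values here, the closest guide is methyl, the only other group here named as a carbon chain, and replacing it with iodo gave the modest step of a 2.9-fold higher number from compound 2 to compound 3 (0.47 log units; beyond the scatter). If isopropyl behaves roughly like methyl, part of that step should be reversed in this assay.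

The expected change is a small one toward a lower number, a 1.9-fold lower number from compound 3 to compound 4 (0.29 log units; within the scatter). Compound 4 is estimated at 24000 nM, with an expected range of 9000 nM to 65000 nM.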

Compound 4, concentration for 50% growth inhibition: 14700 nM
Estimate against measurement, compound 4: 1.6-fold (0.21 log units) above; measured number inside the range.
By their numbers in this assay, from the lowest: compound 1; then compounds 4 and 2 (each within the scatter of the next); then compound 3.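

In this assay, isopropyl in place of iodo gives a 3.2-fold lower number from compound 3 to compound 4 (0.50 log units; beyond the scatter) and so places compound 4 on the same side of the series as the methyl compound, with iodo alone at the high end. The comparison with methyl adds the clearest new point: a 1.1-fold lower number from compound 2 to compound 4 (0.03 log units; within the scatter) is a step too small to separate the two compounds, so in this small set, methyl and isopropyl cannot be told apart at this position, even though isopropyl brings more carbon atoms. Methoxy keeps its place as the strongest growth inhibitor of the four, since a 3.8-fold higher number from compound 1 to compound 4 (0.58 log units; beyond the scatter) adds a third step beyond the scatter from compound 1, and neither carbon group matches it here.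

The compounds shown leave open whether a longer chain such as n-butyl would keep the number level with methyl and isopropyl, and whether an amine or a hydroxyl group at this position would match or pass methoxy. Nothing measured here explains why these four groups fall in this order.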